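This account rests on a few compounds, and the source may have more. Where it says the series, first, only, none or still open, it means among the compounds named here.

Measured so far in a functional assay on SNB-75 cells (Homo sapiens) for antiproliferative activity, with a stated time of 48 h; a lower number here means a stronger inhibitor of growth, a higher number a weaker inhibitor of growth: compound 1 `Cc1cc(O)c(C2=NN(c3ccc(S(N)(=O)=O)cc3)C(c3ccccc3Cl)C2)cc1Cl` gives 8830 nM; compound 2 `COc1ccc(C2CC(c3cc(Cl)c(C)cc3O)=NN2c2ccc(S(N)(=O)=O)cc2)cc1OC` gives 97200 nM.

Compound 2 stands with the higher of the two numbers, its nearest neighbour being compound 1, the gap being an 11-fold higher number from compound 1 to compound 2 (1.04 log units; beyond the scatter). Compound 3 `COc1ccc(C2CC(c3cc(Cl)c(C)cc3O)=NN2c2ccc(S(N)(=O)=O)cc2)c(OC)c1OC` differs from compound 2 by methoxy in place of hydrogen on an aromatic carbon. Among the compounds with values here, the only measured step, an 11-fold higher number from compound 1 to compound 2 (1.04 log units; beyond the scatter), exchanges the whole aryl group on the saturated ring carbon and does not bear directly on adding one methoxy. No step beyond the scatter is therefore expected in this assay. Compound 3 is estimated at 100000 nM, with a range from 40000 nM to 250000 nM. The expected change is a 1.0-fold higher number from compound 2 to compound 3 (0.01 log units; within the scatter).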

Compound 3, concentration for total growth inhibition: 28500 nM
The estimate for compound 3 lay 3.5-fold (0.55 log units) above the measured number, and the stated range ends above it.
By their numbers in this assay, from the lowest: compound 1; then compound 3; then compound 2.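

In this assay, methoxy in place of hydrogen on an aromatic carbon, ortho to a large group, turning 3,4-dimethoxyphenyl into 2,3,4-trimethoxyphenyl, gives a step beyond the scatter (a 3.4-fold lower number from compound 2 to compound 3 (0.53 log units; beyond the scatter)), so this position does affect growth inhibition. The 2,3,4-trimethoxyphenyl group still falls short of 2-chlorophenyl on the saturated ring carbon (a 3.2-fold higher number from compound 1 to compound 3 (0.51 log units; beyond the scatter)). No measurement available accounts for the change.

Going by these compounds, whether an amine, a hydroxyl or a longer ethoxy chain at this position would act like methoxy stays open. So does whether the effect of this methoxy depends on the other two methoxy groups.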